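Solubility notes on the shared core, compounds 1 to 3

This account rests on a few compounds, and the source may have more. Where it says the series, first, only, none or still open, it means among the compounds named here.

Measured so far in a physicochemical assay for solubility, using the shake flask method, in phosphate buffer, measured as kinetic solubility, with a stated time of 20 h, at pH 6.5; a higher number here means a more soluble compound, a lower number a less soluble compound:
- compound 1 `COc1cccc(Nc2cc3[nH]c(-c4cccc(C(F)(F)F)c4)nc3cn2)n1`: in this assay compound 1 gives < 5000 nM, which is a limit of the assay and not a number.
- compound 2 `FC(F)(F)c1cccc(-c2nc3cnc(Nc4cccnn4)cc3[nH]2)c1`: in this assay compound 2 gives < 5000 nM, again a limit of the assay.

Compound 2 therefore stands at the lower reporting limit, and no value sharper than that is known for it. The same holds for compound 1, so that both measured values sit at the limit (the limit of < 5000 nM in this assay, at which 2 of the 2 values shown sit). For the measured compounds named here, the single step measured between members, a step that the two limits leave unreadable from compound 1 to compound 2, is not readable from the two limits and gives no size in either direction.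

Compound 3 `O=C(O)c1ccnc(Nc2cc3[nH]c(-c4cccc(C(F)(F)F)c4)nc3cn2)c1` is the next member to be measured. It differs from compound 2 in one place: 4-carboxypyridin-2-yl in place of pyridazin-3-yl on a nitrogen on an aromatic ring. Going by the values given here, no measured step bears directly on this change, and the one step that exists sets no size to compare against.

With nothing in the measured steps to anchor it, the step of an at least 4.0-fold higher number from compound 2 to compound 3 (0.60 log units; beyond the scatter) is an estimate only. Compound 3 is expected to give about 20000 nM, within a range of 3000 nM to 150000 nM.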

Compound 3, solubility: < 5000 nM
Compound 3: only a limit was reported; the forecaster's own chance of this, stated with the estimate: 30%; middle value at least 4.0-fold (0.60 log units) away from the limit.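

In this assay compound 3 gives < 5000 nM, which is a limit of the assay and not a number. No step among compound 1, compound 2 and compound 3 can be read, because all three stand at the same limit: the limit of < 5000 nM in this assay, at which 3 of the 3 values shown sit.

The compounds shown leave open how far each lies under that limit, and whether the three groups on the nitrogen differ at all in this assay.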